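Nitro in Place of Hydrogen: Expecting Compound 3

A few compounds are considered here, and "the series" means these few. Any claim that something is new, unique, unknown or untested is made for them only; others in the source may bear on it.

Compound 1, `Nc1ccccc1NC(=O)c1ccc(COc2ccccc2)cc1`: 6700 nM
Compound 2, `Nc1cc(F)ccc1NC(=O)c1ccc(COc2ccccc2)cc1`: 7020 nM

Of the two numbers measured in a functional assay on HepG2 cells (Homo sapiens) for antiproliferative activity, read by CCK-8 assay, with a stated time of 72 h (on this read-out lower numbers stand for stronger inhibition and higher numbers for weaker inhibition), compound 1 gives the lowest, yet compound 2 sits so close that no order can be read from them: a 1.0-fold higher number from compound 1 to compound 2 (0.02 log units; within the scatter). Compound 3, `Nc1ccccc1NC(=O)c1ccc(COc2ccc([N+](=O)[O-])cc2)cc1`, departs from compound 1 in one place: nitro in place of hydrogen on an aromatic carbon. Within the data shown here, only one measured step exists, the fluoro for hydrogen from compound 1 to compound 2, and it touched a different ring while staying within the scatter. Among the measured compounds shown here, no measured pair speaks to the phenyl that now carries the nitro group, so the direction of any step is open. For the measured compounds named here, the single step measured here being so small, a modest change at most is expected for compound 3, and its value is estimated at 6500 nM, between 2500 nM and 17000 nM. That estimate means a step of a 1.0-fold lower number from compound 1 to compound 3 (0.01 log units; within the scatter), which is expected to stay within the scatter.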

Compound 3, half-maximal inhibitory concentration: > 32000 nM
Compound 3: a limit, no number; the forecaster's own chance of this, stated with the estimate: 5%; middle value at least 4.9-fold (0.69 log units) away from the limit.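

In this assay compound 3 gives > 32000 nM as its reading, which is a limit of the assay and not a number. Even so, the change from phenyl to 4-nitrophenyl, on an aromatic carbon para to a large group, gives an at least 4.7-fold higher number from compound 1 to compound 3 (0.67 log units; beyond the scatter) as its step, so this ring responds to substitution in a way the fluoro change on the other ring, with a 1.0-fold higher number from compound 1 to compound 2 (0.02 log units; within the scatter) as its step, did not show. The true size of the step stays unknown, and only its lower bound can be read: the limit of > 32000 nM in this assay, at which 1 of the 3 values shown sits.

From the compounds shown here alone, whether the loss belongs to nitro itself or would follow any group at this carbon remains open. An amine, a methoxy group or a fluoro at the same place would be needed to separate the two.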